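A few compounds are considered here, and "the series" means these few. Any claim that something is new, unique, unknown or untested is made for them only; others in the source may bear on it.

In a functional assay on the whole organism (strain C57B/6) with Mus musculus as the target, in the maximal electroshock model (on this read-out lower numbers stand for an effect already at smaller amounts and higher numbers for an effect only at larger amounts of compound), compound 1 `CCCCCCOc1ccc(-n2cnnc2CCCCC)cc1` gives 32.8 mg/kg. Compound 2 `CCCCCCOc1ccc(-n2cnnc2CCCCCC)cc1` reaches only the limit of the assay, > 40 mg/kg. Compound 3 `CCCCCCCCCc1nncn1-c1ccc(OCCCCCC)cc1` likewise reaches only the limit, > 40 mg/kg, so its place in this assay is known solely as a limit, as the limit of > 40 mg/kg in this assay, at which 2 of the 3 values shown sit, states. The step of an at least 1.2-fold higher number from compound 1 to compound 3 (0.08 log units; that floor lies within the scatter) is read against that limit, and the step that the two limits leave unreadable from compound 2 to compound 3 cannot be read at all. Compound 4 `CCCCCCOc1ccc(-n2cnnc2-c2ccc(Cl)cc2)cc1` differs from compound 3 by 4-chlorophenyl in place of nonyl on an aromatic carbon. Among the compounds with values here, none of the measured steps concerns this exchange; all three concern the length of a saturated chain. No direction can therefore be drawn from them. Compound 4 is estimated at 35 mg/kg, within 10 mg/kg to 120 mg/kg, which means an expected step of an at least 1.1-fold lower number from compound 3 to compound 4 (0.05 log units; that floor lies within the scatter), with a real chance that only a limit is reported again.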

Compound 4, dose for half-maximal effect: 19.7 mg/kg
For compound 4 the middle estimate is 1.8-fold (0.25 log units) above the measured one, and the stated range covers the measured number.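

Compound 4 shows that this aromatic carbon of the five-membered ring accepts a group other than a saturated chain and still gives a measured number in this assay. Against the two chains that sit at a limit, the exchange reads only as floors, an at least 2.0-fold lower number from compound 3 to compound 4 (0.30 log units; that floor lies within the scatter) and an at least 2.0-fold lower number from compound 2 to compound 4 (0.30 log units; that floor lies within the scatter): the limit of > 40 mg/kg in this assay, at which 2 of the 4 values shown sit. Against pentyl the exchange gives a 1.7-fold lower number from compound 1 to compound 4 (0.22 log units; within the scatter), so at this position 4-chlorophenyl and pentyl cannot be told apart.

Going by these compounds, what the chlorine itself contributes remains open. So does how a plain phenyl or a benzyl group would read on this carbon.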